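A few compounds are considered here, and "the series" means these few. Any claim that something is new, unique, unknown or untested is made for them only; others in the source may bear on it.

In a functional assay on HepG2 cells (Homo sapiens) for antiproliferative activity, read by MTT assay, with a stated time of 48 h (on this read-out higher numbers stand for weaker inhibition and lower numbers for stronger inhibition), compound 1 `COc1ccc(C2OC(c3ccc4ccccc4c3)=NN2C(C)=O)cc1` gives 3.6 ug/mL and compound 2 `CC(=O)N1N=C(c2ccc3ccccc3c2)OC1c1ccc(C)cc1` gives 2.26 ug/mL, values within the scatter of each other. Compound 3 `CC(=O)N1N=C(c2ccc3ccccc3c2)OC1c1ccsc1` has thiophen-3-yl in place of 4-methylphenyl on a saturated ring carbon. Among the measured compounds shown here, the one measured step is a 1.6-fold lower number from compound 1 to compound 2 (0.20 log units; within the scatter). It exchanges methyl for methoxy on an aromatic carbon rather than replacing the whole group, so it bears only loosely on this change. No step beyond the scatter is expected in this assay, and no direction is favoured. The estimated step is a 1.2-fold higher number from compound 2 to compound 3 (0.06 log units; within the scatter). Compound 3 is expected at 2.6 ug/mL, with an estimated range of 1 ug/mL to 6.5 ug/mL.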

Compound 3, half-maximal inhibitory concentration: 6.82 ug/mL
Estimate against measurement, compound 3: 2.6-fold (0.42 log units) below; the whole stated range lies below it.
By their numbers in this assay, from the lowest: compounds 2, 1 and 3 (each within the scatter of the next, the first and the last beyond it).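

Thiophen-3-yl in place of 4-methylphenyl on the saturated ring carbon gives the first change in the series to pass the scatter, with a 3.0-fold higher number from compound 2 to compound 3 (0.48 log units; beyond the scatter). Thiophen-3-yl in place of 4-methoxyphenyl at the same carbon gives a 1.9-fold higher number from compound 1 to compound 3 (0.28 log units; within the scatter), so the replacement passes the scatter against only one of the two phenyl partners. Nothing on hand accounts for this step.

Still open, going by these compounds, is whether the shift belongs to thiophen-3-yl itself or to any five-membered aromatic ring at this carbon. On these data alone, how a furan-3-yl or a 4-aminophenyl group would read there also remains open.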